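From propyl to but-2-en-1-yl: one small chain change

The source may report more compounds than this note shows. Statements on the series, on what has been measured and on what is new or still open speak of the compounds shown alone.

In a functional assay on P388 cells (Mus musculus) for cytotoxicity (on this read-out higher numbers stand for weaker inhibition and lower numbers for stronger inhibition), compound 1 `COc1ccc(C[C@H]2C(=O)N[C@@H](C)C(=O)N(C)[C@H]3Cc4ccc(cc4)Oc4cc(ccc4OC)C[C@@H](C(=O)N[C@H](C)C(=O)N[C@@H](CS)C(=O)N2C)N(C)C3=O)cc1` gives 363 nM
In this assay compound 2 `COc1ccc(C[C@H]2C(=O)N[C@@H](C)C(=O)N(C)[C@H]3Cc4ccc(cc4)Oc4cc(ccc4OC)C[C@@H](C(=O)N[C@H](C)C(=O)N[C@@H](CC=O)C(=O)N2C)N(C)C3=O)cc1` gives 33.9 nM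
In this assay compound 3 `CCCN1C(=O)[C@@H](C)NC(=O)[C@@H]2Cc3ccc(OC)c(c3)Oc3ccc(cc3)C[C@@H](C(=O)N2C)N(C)C(=O)[C@H](C)NC(=O)[C@H](Cc2ccc(OC)cc2)N(C)C(=O)[C@@H]1C` gives 3.98 nM

Compound 3 stands at 3.98 nM and holds the lowest of the three numbers, with compound 2 and compound 1 both higher by more than the scatter. The next candidate is compound 4 `C/C=C/CN1C(=O)[C@@H](C)NC(=O)[C@@H]2Cc3ccc(OC)c(c3)Oc3ccc(cc3)C[C@@H](C(=O)N2C)N(C)C(=O)[C@H](C)NC(=O)[C@H](Cc2ccc(OC)cc2)N(C)C(=O)[C@@H]1C` and it differs from compound 3 in one place: prop-1-en-1-yl in place of ethyl on a saturated chain carbon bound to an amide-type nitrogen in a ring. In words, prop-1-en-1-yl stands in place of ethyl on a saturated chain carbon bound to an amide-type nitrogen in a ring. Cut one bond further out, the same difference reads propyl to but-2-en-1-yl.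

Among the compounds with values here, only one measured step compares two close relatives here: an 11-fold lower number from compound 1 to compound 2 (1.03 log units; beyond the scatter) with formyl in place of sulfanyl. That step is large, but it swaps other groups at another place, so it offers only a loose guide. Within the data shown here, no measured step shows what a change on this chain does, which leaves the direction open. A small change is therefore expected. For compound 4 the expected step is a 1.3-fold higher number from compound 3 to compound 4 (0.10 log units; within the scatter) and it is not expected to go beyond the scatter. For compound 4 the estimated value is 5 nM with an expected range from 1.5 nM to 18 nM in this estimate.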

Compound 4, half-maximal inhibitory concentration: 9.12 nM
The estimate for compound 4 lay 1.8-fold (0.26 log units) below the measured number; the range from low to high includes it.
By their numbers in this assay, from the lowest: compound 3; then compound 4; then compound 2; then compound 1.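

Within the data shown here, this is the first step that reads the chain on a saturated chain carbon bound to an amide-type nitrogen in a ring: in this assay, replacing ethyl with prop-1-en-1-yl, which turns propyl into but-2-en-1-yl, gives a 2.3-fold higher number from compound 3 to compound 4 (0.36 log units; beyond the scatter). The step is modest but beyond the scatter, so this place on the shared core does respond to a small change in the chain, and the higher number means weaker inhibition, while compound 4 still reads 9.12 nM. Nothing measured here gives a reason for this loss.

The change adds a carbon and a double bond at once, so the compounds shown cannot separate the two, and a saturated butyl group at this place would be the direct test of which one matters. Also open, as far as these compounds go, is how far this place would tolerate a different kind of group, such as a chain ending in an amine or a carboxylic acid, or a much longer chain.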